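A tert-butyl group added to compound 1

The compounds below may be only part of what the source reports. "The series", "measured", "known", "first", "only" and "open" are said of these compounds alone.

Within the data shown here, in a functional assay on SW480 cells (Homo sapiens) for cytotoxicity, read by MTT assay, with a stated time of 48 h (on this read-out higher numbers stand for weaker inhibition and lower numbers for stronger inhibition), compound 1 (`O=c1ccoc2cc(OCc3cn(Cc4ccccc4)nn3)ccc12`) gives 42900 nM, the only exact number so far. Compound 2 (`O=c1ccoc2cc(OCc3cn(Cc4cccc([N+](=O)[O-])c4)nn3)ccc12`) gives > 100000 nM, which is a limit of the assay and not a number. Compound 3 (`CC(C)(C)c1ccc(Cn2cc(COc3ccc4c(=O)ccoc4c3)nn2)cc1`) has not been measured, and it differs from compound 1 as follows: tert-butyl in place of hydrogen on an aromatic carbon. The new tert-butyl sits on an aromatic carbon, para to a large group. Among the measured compounds shown here, only one measured step bears on this change, where nitro replaces hydrogen on an aromatic carbon: an at least 2.3-fold higher number from compound 1 to compound 2 (0.36 log units; beyond the scatter). From the compounds shown here alone, that step is modest, and its full size is unknown. Nitro is also a different group from tert-butyl, and this single step sets no firm direction. The expected result in this assay is no change beyond the scatter, with an estimated 1.1-fold lower number from compound 1 to compound 3 (0.03 log units; within the scatter). For compound 3, the expected value is 40000 nM, within an estimated range of 15000 nM to 100000 nM.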

Compound 3, half-maximal inhibitory concentration: 28800 nM
Estimate against measurement, compound 3: 1.4-fold (0.14 log units) above, within the range that was stated.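

In this assay, tert-butyl in place of hydrogen gives a 1.5-fold lower number from compound 1 to compound 3 (0.17 log units; within the scatter), so this added group of 4 carbon atoms, para to a large group, leaves the number within the scatter of the parent. The earlier nitro change gave an at least 2.3-fold higher number from compound 1 to compound 2 (0.36 log units; beyond the scatter), so the two substituents on this aromatic ring, each replacing a hydrogen, do not act alike on this read-out. Compound 2 stands at a limit of the assay and not at a number, so only the tert-butyl step has an exact size: the limit of > 100000 nM in this assay, at which 1 of the 3 values shown sits.

The compounds shown leave open whether an amine or a carboxylic acid at this same place would move the number beyond the scatter. Compound 1 gives 42900 nM, and the compounds shown also leave open whether any group here could bring that number down beyond the scatter.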